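The source may report more compounds than this note shows. Statements on the series, on what has been measured and on what is new or still open speak of the compounds shown alone.

Among the compounds with values here, compound 1, whose structure is `O=c1cc(/C=C/C=C/c2ccc(O)c(O)c2)oc2ccccc12`, is the weaker of the two compounds measured so far in a physicochemical assay for inhibition, read by fluorescence, with a stated time of 30 min, at 37 degrees C; a higher number here means a weaker inhibitor, a lower number a stronger inhibitor. In this assay compound 1 gives 1300 nM, the highest of the two numbers. Compound 2, with the structure `O=c1cc(/C=C/C=C/c2ccc(O)c(O)c2)oc2cccc(O)c12`, is its nearest neighbour; in this assay compound 2 gives 1100 nM. Within the data shown here, the one step between them, a 1.2-fold lower number from compound 1 to compound 2 (0.07 log units; within the scatter), is too small to count as a change.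

Compound 3, with the structure `O=c1cc(/C=C/C=C/c2ccc(O)c(O)c2)oc2cc(O)ccc12`, is not yet measured. It differs from compound 1 by hydroxy in place of hydrogen on an aromatic carbon. Among the measured compounds shown here, the only measured step that bears on this change is the one from compound 1 to compound 2, where a hydroxy entered the same ring elsewhere and a 1.2-fold lower number from compound 1 to compound 2 (0.07 log units; within the scatter) stayed within the scatter. On that basis no step beyond the scatter is expected for compound 3 in this assay, and the expected step is a 1.2-fold lower number from compound 1 to compound 3 (0.07 log units; within the scatter). The estimate for compound 3 in this assay is 1100 nM, with a range from 500 nM to 2500 nM.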

Compound 3, half-maximal inhibitory concentration: 1600 nM
Estimate against measurement, compound 3: 1.5-fold (0.16 log units) below, and the stated range covers the measured number.
By their numbers in this assay, from the lowest: compounds 2, 1 and 3 (each within the scatter of the next).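

In this assay the hydroxy at this place, on an aromatic carbon meta to a fused ring and para to a fused ring, gives a step that stays within the scatter (a 1.2-fold higher number from compound 1 to compound 3 (0.09 log units; within the scatter)). The earlier step (a 1.2-fold lower number from compound 1 to compound 2 (0.07 log units; within the scatter)) showed this for one place on the ring; hydroxy in place of hydrogen has now been read at a second place, again with no change beyond the scatter. Nothing measured on these compounds accounts for this result.

The compounds shown leave open whether a group other than hydroxy, such as a methoxy group or an amine, would give a step beyond the scatter at this place. They also leave open whether hydroxy would do so on any other aromatic carbon of this ring.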